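Chloro in place of bromo on compound 1

The source may report more compounds than this note shows. Statements on the series, on what has been measured and on what is new or still open speak of the compounds shown alone.

For the measured compounds named here, in an ADME assay on BJ cells (Homo sapiens) for cytotoxicity, read by fluorescence, with a stated time of 24 h (on this read-out lower numbers stand for stronger inhibition and higher numbers for weaker inhibition), compound 1 (`O=C1N/C(=N/N=C/c2c(-c3ccc(Br)cc3)[nH]c3ccccc23)SC1CCO`) gives 29200 nM, the higher of the two numbers measured so far. Going by the values given here, the only other measured compound, compound 2 (`CCC1S/C(=N\N=C\c2c(-c3ccc(Br)cc3)[nH]c3ccccc23)NC1=O`), gives 7450 nM.

Compound 3 (`O=C1N/C(=N/N=C/c2c(-c3ccc(Cl)cc3)[nH]c3ccccc23)SC1CCO`) differs from compound 1 in one place: chloro in place of bromo on an aromatic carbon. This puts chloro in place of bromo on an aromatic carbon, para to a large group.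

Among the compounds with values here, the only measured step, a 3.9-fold lower number from compound 1 to compound 2 (0.59 log units; beyond the scatter), is modest and lies on the saturated chain, so it leaves the halogen untouched. Within the data shown here, it bears only loosely on this change, and no measured pair compares bromo with chloro. No step beyond the scatter is therefore expected in this assay, and no direction is favoured. The expected step is a 1.1-fold lower number from compound 1 to compound 3 (0.05 log units; within the scatter).

For compound 3, the estimated value is 26000 nM, with an expected range of 12000 nM to 55000 nM.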

Compound 3, half-maximal inhibitory concentration: 22400 nM
Beside the measured number, compound 3's estimate is 1.2-fold (0.06 log units) above it; low and high end bracket the measured number.
By their numbers in this assay, from the lowest: compound 2; then compounds 3 and 1 (each within the scatter of the next).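

In this assay, for the compounds shown here, a 1.3-fold lower number from compound 1 to compound 3 (0.12 log units; within the scatter) gives the first direct reading of a halogen change at this aromatic carbon, para to a large group: going from 4-bromophenyl to 4-chlorophenyl with the hydroxy-bearing chain of compound 1 in place leaves the number within the scatter. In contrast, the chain change in a 3.9-fold lower number from compound 1 to compound 2 (0.59 log units; beyond the scatter) lies beyond the scatter, so of the two single changes shown, only the one on the saturated chain gives a step that can be read as real. Nothing available explains either step.

As far as these compounds go, it remains open whether the same swap, made on compound 2, would also stay within the scatter in this assay. From the compounds shown here alone, it is also open whether a non-halogen group on this aromatic carbon, such as methoxy or an amine, would give a step beyond the scatter.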